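Pyrimidinyl for methylphenyl on the cyclopropane of compound 3

A few compounds are considered here, and "the series" means these few. Any claim that something is new, unique, unknown or untested is made for them only; others in the source may bear on it.

Three compounds of the series have a number in a functional assay for agonist activity at G protein-coupled receptor 88 (Homo sapiens), read by HTRF and cAMP accumulation; on this read-out lower numbers stand for an effect already at smaller amounts and higher numbers for an effect only at larger amounts of compound. Compound 1 `CC(C)[C@H](N)CN(C(=O)[C@@H]1C[C@H]1c1ccccc1)c1ccc(-c2ccccc2)cc1` gives 1.1 nM in this assay. Among the compounds with values here, compound 2 `CC(C)CCNCCN(C(=O)[C@@H]1C[C@H]1c1ccccc1)c1ccc(-c2ccccc2)cc1` gives 5.1 nM in this assay, and the step of a 4.6-fold higher number from compound 1 to compound 2 (0.67 log units; beyond the scatter) is the only single-site comparison measured so far. Compound 3 `CC[C@H](C)[C@H](N)CN(C(=O)[C@@H]1C[C@H]1c1cccc(C)c1)c1ccc(-c2ccccc2)cc1` gives 1200 nM in this assay and stands highest of the three, above compound 2 and further still above compound 1, in both cases beyond the scatter.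

Compound 4 `CC[C@H](C)[C@H](N)CN(C(=O)[C@@H]1C[C@H]1c1cncnc1)c1ccc(-c2ccccc2)cc1` differs from compound 3 by pyrimidin-5-yl in place of 3-methylphenyl on a saturated ring carbon. Within the data shown here, no measured step touches this place: the one step on record changes the chain on the amide nitrogen and says nothing about the ring on the three-membered ring. The numbers therefore give no direction, and the expectation is a step of a 1.7-fold higher number from compound 3 to compound 4 (0.22 log units; within the scatter), held with a wide range. Compound 4 is estimated at 2000 nM in this assay, expected to fall between 400 nM and 10000 nM.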

Compound 4, half-maximal effective concentration: 19000 nM
Compound 4: middle estimate off by 9.5-fold (0.98 log units), on the low side; measured number outside the range, above it.
By their numbers in this assay, from the lowest: compound 1; then compound 2; then compound 3; then compound 4.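

Pyrimidin-5-yl in place of 3-methylphenyl on a saturated ring carbon of the three-membered ring gives a 16-fold higher number from compound 3 to compound 4 (1.20 log units; beyond the scatter) in this assay, so this place, untouched by the earlier step, clearly affects the read-out. The exchange removes the methyl and also brings hetero atoms and hydrogen-bond acceptors into the aromatic ring, and this single step cannot divide its effect among those changes. Nothing at hand accounts for the size of the step.

Still open, going by these compounds, is where an unsubstituted phenyl or a pyridin-3-yl, with one ring nitrogen, would stand on the chain of compound 3, which would separate the loss of the methyl from the entry of the ring nitrogens. Also open, on these data alone, is whether pyrimidin-5-yl would cost as much on the chain of compound 1.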